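This account rests on a few compounds, and the source may have more. Where it says the series, first, only, none or still open, it means among the compounds named here.

In a functional assay on HeLa cells (Homo sapiens) for antiproliferative activity, read by sulforhodamine B assay, with a stated time of 48 h (a higher number here means a weaker inhibitor of growth, a lower number a stronger inhibitor of growth), three compounds have been measured:
- compound 1 `O=C1COc2ccccc2N1CCCn1cc(-c2ccccc2)nn1` gives 9000 nM
- compound 2 `O=C1COc2ccccc2N1CCCn1cc(-c2ccccn2)nn1` gives 10000 nM
- compound 3 `O=C1COc2ccccc2N1CCCn1cc(CO)nn1` gives 7300 nM

Compound 3 stands level with the other two, since repeated measurements of this kind scatter by about as much as these values differ. The steps to it are a 1.2-fold lower number from compound 1 to compound 3 (0.09 log units; within the scatter) and a 1.4-fold lower number from compound 2 to compound 3 (0.14 log units; within the scatter), and both lie within the scatter.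

Compound 4 `O=C1COc2ccccc2N1CCCn1cc(C2(O)CCCCC2)nn1` keeps the shared core and has 1-hydroxycyclohexyl in place of hydroxymethyl on an aromatic carbon.

The three measured steps all change the group on this same carbon. Besides the two above, there is a 1.1-fold higher number from compound 1 to compound 2 (0.05 log units; within the scatter). None of them leaves the scatter, so swapping this group has not yet moved the number. Among the measured compounds shown here, no measured compound carries 1-hydroxycyclohexyl, however, so the evidence is only indirect.

The expected change is therefore none beyond the scatter, an estimated 1.0-fold lower number from compound 3 to compound 4 (0.02 log units; within the scatter).

For compound 4 the estimated value is 7000 nM, with an expected range from 3000 nM to 15000 nM.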

Compound 4, concentration for 50% growth inhibition: 2000 nM
Beside the measured number, compound 4's estimate is 3.5-fold (0.54 log units) above it, outside the stated range (below it).
By their numbers in this assay, from the lowest: compound 4; then compounds 3, 1 and 2 (each within the scatter of the next).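

In this assay, among the compounds shown here, the group on this aromatic carbon can move the number after all, as 1-hydroxycyclohexyl gives the only steps beyond the scatter in this set (a 3.7-fold lower number from compound 3 to compound 4 (0.56 log units; beyond the scatter); a 4.5-fold lower number from compound 1 to compound 4 (0.65 log units; beyond the scatter); a 5.0-fold lower number from compound 2 to compound 4 (0.70 log units; beyond the scatter)). Neither part of the new group is enough by itself among these compounds: compound 3 carries a hydroxyl-bearing group without a ring, compounds 1 and 2 carry a six-membered aromatic ring without a hydroxyl, and these three stand level, while compound 4 joins a hydroxyl to a six-membered ring of carbon only. No measurement here explains this gain.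

Plain cyclohexyl would test whether the hydroxyl matters once the ring is present. A 1-hydroxycyclopentyl group, or a 1-aminocyclohexyl group, would show how much the ring size and the oxygen each count.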